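A few compounds are considered here, and "the series" means these few. Any claim that something is new, unique, unknown or untested is made for them only; others in the source may bear on it.

In an in vitro ADME assay on microsomes from liver (Homo sapiens) for metabolic stability, using NADPH (a lower number here means slower removal, a higher number faster removal of the compound), compound 1 (`COc1ccc(Br)cc1Cn1c(C(=O)NCC(C)(C)CO)cc2cc(C#N)ccc21`) gives 104 mL.min-1.g-1, while compound 2 (`CC(C)(O)CCNC(=O)c1cc2cc(C#N)ccc2n1Cc1cccc(OC(F)(F)F)c1`) gives 9 mL.min-1.g-1, the lower of the two numbers, with a gap beyond the usual scatter. Compound 3 (`N#Cc1ccc2c(c1)cc(C(=O)NCCC(O)(C(F)(F)F)C(F)(F)F)n2Cc1cccc(OC(F)(F)F)c1`) differs from compound 2 in one group: 2,2,2-trifluoro-1-hydroxy-1-(trifluoromethyl)ethyl in place of 1-hydroxy-1-methylethyl on a saturated chain carbon, two bonds along the chain from an amide-type nitrogen, with 2,2,2-trifluoro-1-hydroxy-1-(trifluoromethyl)ethyl in place of 1-hydroxy-1-methylethyl on a saturated chain carbon, two bonds along the chain from an amide-type nitrogen. Going by the values given here, no measured pair shows this change, so only a modest rise is expected, with the estimated step of a 1.7-fold higher number from compound 2 to compound 3 (0.22 log units; within the scatter) lying close to the scatter. For compound 3 the estimate is 15 mL.min-1.g-1, with an expected range of 5 mL.min-1.g-1 to 45 mL.min-1.g-1.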

Compound 3, intrinsic clearance in microsomes: 20 mL.min-1.g-1
Compound 3: the middle estimate sits 1.3-fold (0.12 log units) below what was measured; measured number inside the range.
By their numbers in this assay, from the lowest: compound 2; then compound 3; then compound 1.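

Replacing 1-hydroxy-1-methylethyl with 2,2,2-trifluoro-1-hydroxy-1-(trifluoromethyl)ethyl gives a 2.2-fold higher number from compound 2 to compound 3 (0.35 log units; beyond the scatter) in this assay. Going by these compounds alone, this is the first single-place comparison here, and it shows that this position on the chain responds to the change, though only modestly, even with 10 heavy atoms entering for 4. No experimental evidence here accounts for the step. The compounds shown leave open how an amine, a carboxylic acid or a longer chain at this place would behave. They also leave open whether the same change gives a similar step on another core.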